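The source may hold more compounds than are shown below. What is called first, only, known or untested is meant among the compounds shown, and "the series" means these compounds.

Measured in a functional assay on A549 cells (Homo sapiens) for cytotoxicity, read by CCK-8 assay; on this read-out higher numbers stand for weaker inhibition and lower numbers for stronger inhibition:
- compound 1 `O=C(Nc1ccc(O)cc1)c1ncc(-c2ccccc2)o1`: 1080 nM
- compound 2 `Cc1ccc(NC(=O)c2ncc(-c3ccccc3)o2)cc1`: > 30000 nM (a limit)

Going by the values given here, compound 1 holds the only numerical value so far, since the entry for compound 2 is a limit of the assay. Compound 3 `O=C(Nc1ccc(Cl)cc1)c1ncc(-c2ccccc2)o1` differs from compound 1 by chloro in place of hydroxy on an aromatic carbon. Among the compounds with values here, the one measured step at this place, methyl in place of hydroxy, is large and gives an at least 27-fold higher number from compound 1 to compound 2 (1.44 log units; beyond the scatter). On that basis, a large move toward a higher number is also expected in this assay, with the estimated step being an 11-fold higher number from compound 1 to compound 3 (1.05 log units; beyond the scatter). For compound 3 the expected value is 12000 nM, with an estimated range of 3000 nM to 30000 nM.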

Compound 3, half-maximal inhibitory concentration: > 30000 nM
Compound 3: only a limit was reported (the forecaster's own chance of this, stated with the estimate: 40%); middle value at least 2.5-fold (0.39 log units) away from the limit.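

In this assay, chloro in place of hydroxy on the aromatic carbon gives an at least 27-fold higher number from compound 1 to compound 3 (1.44 log units; beyond the scatter), so the loss seen with methyl recurs with a second, different group. Among the compounds shown, only the 4-hydroxyphenyl compound 1 gives a numerical value. The step between compound 2 and compound 3 cannot be read, since both entries are limits: the limit of > 30000 nM in this assay, at which 2 of the 3 values shown sit.

Still open, from the compounds shown here alone, is whether an amine or a methoxy group at this place would give a numerical value like that of compound 1, or whether hydroxy alone does.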